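The compounds below may be only part of what the source reports. "The series", "measured", "known", "first", "only" and "open" are said of these compounds alone.

Measured so far in a functional assay on PC-3 cells (Homo sapiens) for cytotoxicity, read by sulforhodamine B assay, with a stated time of 48 h; a higher number here means a weaker inhibitor, a lower number a stronger inhibitor:

- compound 1 `CC(=O)N1N=C(c2cccc3ccccc23)CC1/C=C/c1ccccc1` gives 21100 nM
- compound 2 `O=CCN1N=C(c2ccc3ccccc3c2)CC1c1cccc([N+](=O)[O-])c1` gives 2980 nM

Compound 2, at 2980 nM and so the stronger of the pair, sits lower than compound 1, and that gap lies beyond the usual scatter. The two compounds differ in more than one place, so their values alone do not tie the gap to any single group.

Compound 3 `COc1ccc(C2CC(c3ccc4ccccc4c3)=NN2CC=O)cc1O` is still unmeasured. It differs from compound 2 at one place (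
3-hydroxy-4-methoxyphenyl in place of 3-nitrophenyl on a saturated ring carbon) with 3-hydroxy-4-methoxyphenyl in place of 3-nitrophenyl on a saturated ring carbon. No measured pair shows this swap, so the expectation rests on compound 2 at 2980 nM and has no firm direction. The step expected is a 1.2-fold lower number from compound 2 to compound 3 (0.08 log units; within the scatter) and it is not expected to pass the scatter. For compound 3 the estimate is 2500 nM with 800 nM and 8000 nM as the expected ends of its range.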

Compound 3, half-maximal inhibitory concentration: 2040 nM
Beside the measured number, compound 3's estimate is 1.2-fold (0.09 log units) above it; the measured number falls inside the stated range.
By their numbers in this assay, from the lowest: compounds 3 and 2 (each within the scatter of the next); then compound 1.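

In this assay the swap of 3-nitrophenyl for 3-hydroxy-4-methoxyphenyl on the saturated ring carbon gives a 1.5-fold lower number from compound 2 to compound 3 (0.16 log units; within the scatter) and so leaves the two compounds indistinguishable. Among the compounds shown here, this is the first pair that differs in one place, and it shows that this position can carry either aromatic group with no step beyond the scatter, even though only the entering group has a hydrogen-bond donor. Nothing at hand explains why the two values stay so close.

From the compounds shown here alone, whether a quite different group on this ring carbon, such as an aminophenyl or a carboxyphenyl, would also leave the number within the scatter remains open. For the compounds shown here, also open is how far the number depends on the formylmethyl group, since no pair here changes that group alone.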